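Pyridin-2-yl in place of 4-aminophenyl: working notes

The source may hold more compounds than are shown below. What is called first, only, known or untested is meant among the compounds shown, and "the series" means these compounds.

Measured so far in a functional assay on MIA PaCa-2 cells (Homo sapiens) for cytotoxicity, read by MTT assay, with a stated time of 4 h (a lower number here means a stronger inhibitor, a higher number a weaker inhibitor), for the series:
- compound 1 `COC1=CC(=O)c2c(COc3ccc([N+](=O)[O-])cc3)c(C)n(C)c2C1=O` gives 638 nM
- compound 2 `COC1=CC(=O)c2c(COc3ccc(N)cc3)c(C)n(C)c2C1=O` gives 504 nM
- compound 3 `COC1=CC(=O)c2c(COc3ccc(C(F)(F)F)cc3)c(C)n(C)c2C1=O` gives 496 nM

Compound 2 stands within the scatter of both compound 1 and compound 3. Next is compound 4 `COC1=CC(=O)c2c(COc3ccccn3)c(C)n(C)c2C1=O` with the change pyridin-2-yl in place of 4-aminophenyl on an oxygen on a saturated carbon on the same core. Going by the values given here, no measured step covers this exact change. The closest evidence is a 1.3-fold lower number from compound 1 to compound 2 (0.10 log units; within the scatter) together with a 1.3-fold lower number from compound 1 to compound 3 (0.11 log units; within the scatter) and a 1.0-fold lower number from compound 2 to compound 3 (0.01 log units; within the scatter), each within the scatter, yet all three keep the ring of carbon only. No step beyond the scatter is therefore expected in this assay for now. The estimate means a 1.1-fold higher number from compound 2 to compound 4 (0.04 log units; within the scatter) as the expected step. The expected value for compound 4 is 550 nM within an estimated range of 250 nM to 1200 nM for now.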

Compound 4, half-maximal inhibitory concentration: 9580 nM
Estimate against measurement, compound 4: 17-fold (1.24 log units) below, and the stated range ends below it.
By their numbers in this assay, from the lowest: compounds 3, 2 and 1 (each within the scatter of the next); then compound 4.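

This position on the shared core is not indifferent to the ring on the oxygen in this assay. Nitro, amino and trifluoromethyl on the carbon-only ring stayed within the scatter of one another, whereas pyridin-2-yl in place of 4-aminophenyl gives a 19-fold higher number from compound 2 to compound 4 (1.28 log units; beyond the scatter) and sets compound 4 apart from the others. The change both puts a nitrogen into the ring and removes the amino group, so the two cannot be separated here, and an unsubstituted phenyl or a pyridin-3-yl would be needed to part them. Nothing measured here gives a cause for the step.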